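This account rests on a few compounds, and the source may have more. Where it says the series, first, only, none or still open, it means among the compounds named here.

Measured so far in an assay on CHO cells for displacement of a labelled ligand from adenosine receptor A1 (Homo sapiens); on this read-out higher numbers stand for weaker inhibition and lower numbers for stronger inhibition:
compound 1 `CCCn1cnc2c(N)nc(NCc3ccccc3)nc21` — 7600 nM
compound 2 `CCCn1cnc2c(N)nc(NCCCc3ccccc3)nc21` — 3640 nM
compound 3 `CCCn1c(Br)nc2c(N)nc(NCc3ccccc3)nc21` — 358 nM

Compound 2 stands second highest of these three numbers: compound 1 lies somewhat higher, and compound 3 lies far lower. Compound 4 `CCCn1c(Br)nc2c(N)nc(NCCCc3ccccc3)nc21` differs from compound 2 by one change, (bromo in place of hydrogen on an aromatic carbon). The same change has been seen once already, in the shared core, as a 21-fold lower number from compound 1 to compound 3 (1.33 log units; beyond the scatter), a large drop in this assay. Since compound 4 applies that change to compound 2, a step of comparable size in the same direction is expected, that is a 20-fold lower number from compound 2 to compound 4 (1.31 log units; beyond the scatter). Compound 4 is therefore expected to give about 180 nM, with a likely range from 60 nM to 550 nM.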

Compound 4, inhibition constant: 583 nM
Compound 4: the middle estimate sits 3.2-fold (0.51 log units) below what was measured, outside the stated range (above it).
By their numbers in this assay, from the lowest: compounds 3 and 4 (each within the scatter of the next); then compound 2; then compound 1.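

In this assay, bromo on this aromatic carbon also lowers the number on a second core, with a 6.2-fold lower number from compound 2 to compound 4 (0.80 log units; beyond the scatter), so the direction of the change holds in both pairs shown. The size of the step, however, depends on the rest of the molecule: the same change on two cores in this assay, a 21-fold lower number (1.33 log units; beyond the scatter) from compound 1 to compound 3 and a 6.2-fold lower number (0.80 log units; beyond the scatter) from compound 2 to compound 4, 3.4-fold (0.53 log units) apart, beyond the scatter of two such steps With bromo in place, the two side chains no longer separate clearly, with a 1.6-fold higher number from compound 3 to compound 4 (0.21 log units; within the scatter).

Only hydrogen and bromo appear at this carbon. On these data alone, whether chloro, methyl or an amine there would also lower the number remains open, as does how the step would change with other side chains.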